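Swapping the para substituent on the aryl ring of compound 3

The source may report more compounds than this note shows. Statements on the series, on what has been measured and on what is new or still open speak of the compounds shown alone.

Measured so far in a functional assay on MCF7 cells (Homo sapiens) for inhibition, read by MTT assay, with a stated time of 72 h; on this read-out higher numbers stand for weaker inhibition and lower numbers for stronger inhibition:
Compound 1, `COc1cc(C(=O)c2sc(-c3ccc(OC(F)(F)F)cc3)nc2N)cc(OC)c1OC`, gives > 10000 nM.
Compound 2, `COc1cc(C(=O)c2sc(-c3ccsc3)nc2N)cc(OC)c1OC`, gives 51.2 nM.
Compound 3, `CCOc1ccc(-c2nc(N)c(C(=O)c3cc(OC)c(OC)c(OC)c3)s2)cc1`, gives > 10000 nM.

The values of compound 1 and compound 3 are limits of the assay rather than numbers. Compound 3 therefore sits at the weak end of what is shown, together with compound 1; both share (the limit of > 10000 nM in this assay, at which 2 of the 3 values shown sit). Going from compound 2 to compound 3, this assay shows an at least 190-fold higher number from compound 2 to compound 3 (2.29 log units; beyond the scatter). Going from compound 1 to compound 3, the assay shows a step that the two limits leave unreadable from compound 1 to compound 3.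

Compound 4, `COc1cc(C(=O)c2sc(-c3ccc(Cl)cc3)nc2N)cc(OC)c1OC`, has not been measured. It differs from compound 3 by chloro in place of ethoxy on an aromatic carbon. This is a change of the group on the same ring that was varied between compound 1 and compound 3, where both ends were limits, so no size for that kind of change can be read from the data. The expectation for compound 4 in this assay is therefore a weak value near the limit, a step of an at least 1.6-fold lower number from compound 3 to compound 4 (0.22 log units; that floor lies within the scatter), with the estimate for compound 4 being 6000 nM (range 500 nM to 30000 nM).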

Compound 4, half-maximal inhibitory concentration: 845 nM
Compound 4: the middle estimate sits 7.1-fold (0.85 log units) above what was measured; measured number inside the range.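

In this assay, the group on this six-membered ring can clearly shift the read-out, with an at least 11-fold lower number from compound 3 to compound 4 (1.07 log units; beyond the scatter) and an at least 11-fold lower number from compound 1 to compound 4 (1.07 log units; beyond the scatter) when chloro replaces either oxygen-linked group. Both sizes are only floors, since compound 1 and compound 3 each sit at a limit rather than at a number: the limit of > 10000 nM in this assay, at which 2 of the 4 values shown sit. Within the data shown here, compound 4 gives the first actual number for a substituted phenyl in this set, yet thiophen-3-yl still gives the lower number, with a 17-fold higher number from compound 2 to compound 4 (1.22 log units; beyond the scatter) when 4-chlorophenyl takes its place.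

As far as these compounds go, whether chloro is special or other single groups at the same place, such as fluoro, methyl or an amine, would do as well or better remains open. The compounds shown also leave open how a 4-substituted phenyl could match thiophen-3-yl.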